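A few compounds are considered here, and "the series" means these few. Any claim that something is new, unique, unknown or untested is made for them only; others in the source may bear on it.

Measured so far:
compound 1 `COc1cccc(-c2ccc([C@H]3S[C@@H](C)C(=O)Nc4c3c(C)nn4-c3ccccc3C)cc2)c1` — 1800 nM
compound 2 `Cc1nn(-c2ccccc2C(F)(F)F)c2c1C(c1ccc(Oc3ccccc3)cc1)SC(C)C(=O)N2` — 2000 nM

In an assay on isolated protein for agonist activity at Bile acid receptor (Homo sapiens), read by AlphaScreen, with a stated time of 30 min (on this read-out higher numbers stand for an effect only at larger amounts of compound and lower numbers for an effect already at smaller amounts), compound 1 gives 1800 nM, and compound 2 gives 2000 nM; the two numbers lie within the scatter of each other, so nothing separates them. Compound 3 `Cc1ccccc1-n1nc(C)c2c1NC(=O)[C@H](C)S[C@@H]2c1ccc(-c2ccc(C(=O)O)cc2)cc1` is not yet measured. It differs from compound 1 in one place: 4-carboxyphenyl in place of 3-methoxyphenyl on an aromatic carbon. For the measured compounds named here, no step between two measured compounds covers such a change, so the expectation rests on compound 1 alone. A modest lowering is expected, a 2.3-fold lower number from compound 1 to compound 3 (0.35 log units; beyond the scatter), with a real chance that the step stays within the scatter. The estimate for compound 3 in this assay is 800 nM, between 200 nM and 3000 nM.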

Compound 3, half-maximal effective concentration: "not active" (no number reported)
No number was reported for compound 3; the estimate stays without a comparison.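

In this assay, for the compounds shown here, compound 3 is reported as not active without a number, so no step from compound 1 can be read. The compounds shown leave open what lies behind this result, and no available evidence bears on it.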